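Cytotoxicity notes on the shared core series

A few compounds are considered here, and "the series" means these few. Any claim that something is new, unique, unknown or untested is made for them only; others in the source may bear on it.

Measured so far:
compound 1 `CCN(CC)c1cc2[nH]c(C3CCCCC3)nc2cc1NC(=O)OCC(F)(F)F` — > 100 ug/mL
compound 2 `CCCCOC(=O)Nc1cc2nc(C3CCCCC3)[nH]c2cc1N(C)CCN(C)C` — > 100 ug/mL

In an ADME assay on Vero cells (Chlorocebus sabaeus) for cytotoxicity, read by resazurin assay, with a stated time of 3 days (a lower number here means a stronger inhibitor, a higher number a weaker inhibitor), compound 1 gives > 100 ug/mL, which is a limit of the assay rather than a number. Compound 2 in this assay gives > 100 ug/mL, again a limit. Compound 2 therefore stands at the limit of > 100 ug/mL in this assay, at which 2 of the 2 values shown sit, and no number separates it from compound 1 on the values shown.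

Compound 3 `CCCCOC(=O)Nc1cc2nc(C3CCCCC3)[nH]c2cc1N(CC)CC` is not yet measured in this assay. It differs from compound 2 in one place: diethylamino in place of (2-(dimethylamino)ethyl)(methyl)amino on an aromatic carbon. Within the data shown here, no step between measured compounds is available, so the expectation rests only on the two limits already seen. The step from compound 2 to compound 3 is expected to be a step that the limit leaves unreadable from compound 2 to compound 3, that is, none beyond the scatter. Compound 3 is accordingly estimated at 120 ug/mL, with a range of 60 ug/mL to 300 ug/mL, and is most likely to be reported again only as a limit.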

Compound 3, half-maximal inhibitory concentration: > 100 ug/mL
Compound 3 gave a limit, no number; the forecaster's own chance of this, stated with the estimate: 80%; the middle value lies beyond the limit too.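

Compound 3 gives > 100 ug/mL in this assay as a limit, not a number. Among these compounds, compound 1, compound 2 and compound 3 all sit at the same limit, so no step among them can be read. The compounds shown leave open whether either exchanged group changes the result in this assay at all.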